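Opening the Amine Ring: From Piperidin-1-yl to Diethylamino

This account rests on a few compounds, and the source may have more. Where it says the series, first, only, none or still open, it means among the compounds named here.

Two compounds have been measured in an in vitro functional assay on cells (blood brain barrier) for antagonist activity at advanced glycosylation end product-specific receptor (Mus musculus), read by fluorescence, tested at 10 uM; on this read-out higher numbers stand for more inhibition at the one concentration tested (going by the name of the read-out) and lower numbers for less inhibition:
Compound 1 `CCCCc1sc(-c2ccc(OCC3CCCN(CC)C3)cc2)nc1-c1ccc(Oc2ccc(Cl)cc2)cc1` gives 77.5%.
Compound 2 `CCCCc1sc(-c2ccc(OCCCN3CCCCC3)cc2)nc1-c1ccc(Oc2ccc(Cl)cc2)cc1` gives 64.3%.

Among the compounds with values here, compound 2 holds the lower of these two numbers; the only measured step is a number 13.2 percentage points lower from compound 1 to compound 2 (beyond the scatter). Compound 3 `CCCCc1sc(-c2ccc(OCCCN(CC)CC)cc2)nc1-c1ccc(Oc2ccc(Cl)cc2)cc1` differs from compound 2 by diethylamino in place of piperidin-1-yl on a saturated chain carbon, three bonds along the chain from an oxygen on an aromatic ring. Within the data shown here, no measured step involves this change: the single known step concerns a different arrangement of the amine and chain. With nothing to build on, the step is expected to stay within the scatter, a number 4.3 percentage points lower from compound 2 to compound 3 (within the scatter). Compound 3 is therefore estimated at 60%, within a range from 42% to 78%.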

Compound 3, a percentage reported as inhibition, at one concentration (the size of the read-out at that concentration, not a potency): 73.3%
Beside the measured number, compound 3's estimate is 13.3 percentage points below it; the range from low to high includes it.
By their numbers in this assay, from the lowest: compounds 2, 3 and 1 (each within the scatter of the next, the first and the last beyond it).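

In this assay, replacing piperidin-1-yl with diethylamino on the propyl chain gives a number 9 percentage points higher from compound 2 to compound 3 (within the scatter) and so shows that a closed ring on this nitrogen is not needed for a reading of this size. The other new step, a number 4.2 percentage points lower from compound 1 to compound 3 (within the scatter), means that compound 3 cannot be told apart from either compound, even though those two differ clearly. No measurement at hand explains these numbers. Going by these compounds, it remains open whether a smaller amine such as dimethylamino, or a ring such as morpholin-4-yl, would hold the reading on this chain.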